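The source may hold more compounds than are shown below. What is called first, only, known or untested is meant among the compounds shown, and "the series" means these compounds.

Compound 1 `C[C@@H](Cn1ccc(-c2ccc(C#N)c(Cl)c2)n1)NS(=O)(=O)c1cn(C)cn1` carries a methylated imidazole sulfonamide on the shared core; in an ADME assay on PC-3 cells (Homo sapiens) for cytotoxicity, read by CCK-8 assay, with a stated time of 6 days (a lower number here means a stronger inhibitor, a higher number a weaker inhibitor), compound 1 gives only a limit, > 30000 nM, and the limit of > 30000 nM in this assay, at which 1 of the 2 values shown sits, marks that limit. Compound 2 `C[C@@H](Cn1ccc(-c2ccc(C#N)c(Cl)c2)n1)Nc1ccncc1` bears a pyridin-4-yl on the amine nitrogen; in this assay compound 2 stands at "not determined" (no result reported), so no number places it. Compound 3 `C[C@@H](Cn1ccc(-c2ccc(C#N)c(Cl)c2)n1)Nc1cncnc1` differs by pyrimidin-5-yl in place of pyridin-4-yl on an amine nitrogen. With no measured step shown between these compounds, no direction beyond the scatter can be anticipated for this assay. Compound 3 is expected to give about 30000 nM, in a range from 10000 nM to 100000 nM.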

Compound 3, half-maximal inhibitory concentration: > 30000 nM
Compound 3: only a limit was reported; the forecaster's own chance of this, stated with the estimate: 70%; the middle value lies on the limit itself.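

Compound 1 and compound 3 each give only a limit in this assay, so no step can be read between them. Still open, as far as these compounds go, is whether any group on the amine nitrogen gives a real number in this assay.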